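Swapping the chloroethyl chain for a trifluoromethylphenyl ring

This account rests on a few compounds, and the source may have more. Where it says the series, first, only, none or still open, it means among the compounds named here.

Compound 1 `CN(C)c1ccc(C2CC(c3ccc(-n4cncn4)cc3)=NN2)cc1` and compound 2 `CN1CCN(c2ccc(C3=NN(C(=O)CCCl)C(c4ccc(N(C)C)cc4)C3)cc2)CC1` were both tested in a functional assay on HCC1806 cells (Homo sapiens) for inhibition, read by sulforhodamine B assay, tested at 10 uM; a lower number here means less inhibition, a higher number more inhibition at the concentration tested (going by the name of the read-out). Compound 1 gives 6.8%, and compound 2 gives 1.7%; both numbers are small, and the gap between them lies within the usual scatter, so neither compound shows clear inhibition. Compound 3 `CN1CCN(c2ccc(C3=NN(C(=O)c4ccc(C(F)(F)F)cc4)C(c4ccc(N(C)C)cc4)C3)cc2)CC1` differs from compound 2 in one place: 4-(trifluoromethyl)phenyl in place of 2-chloroethyl on a carbonyl carbon. Among the measured compounds shown here, no measured pair shows what such a change does here. Compound 3 is therefore expected to stay close to compound 2, with a step of a number 3.3 percentage points higher from compound 2 to compound 3 (within the scatter) that is not expected to go beyond the scatter. The estimate for compound 3 is 5%, with a range from -8% to 25%.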

Compound 3, a percentage reported as inhibition, at one concentration (the size of the read-out at that concentration, not a potency): 84.1%
For compound 3 the middle estimate is 79.1 percentage points below the measured one; measured number outside the range, above it.
By their numbers in this assay, from the lowest: compounds 2 and 1 (each within the scatter of the next); then compound 3.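

This carbonyl carbon, bound to an amide-type nitrogen in a ring, proves to be a sensitive place: in this assay, putting 4-(trifluoromethyl)phenyl in place of 2-chloroethyl gives a number 82.4 percentage points higher from compound 2 to compound 3 (beyond the scatter). One change at this position, with the rest of the molecule the same, separates almost no inhibition from strong inhibition at the concentration tested. Nothing available here explains this difference. On these data alone, whether the gain comes from the aromatic ring or from its trifluoromethyl group stays open. So does what a plain phenyl ring or a longer carbon chain on this carbonyl would give.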